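The source may hold more compounds than are shown below. What is called first, only, known or untested is meant among the compounds shown, and "the series" means these compounds.

Measured so far in an ADME assay on C2C12 cells (Mus musculus) for cytotoxicity; on this read-out higher numbers stand for lower toxicity in this test and lower numbers for higher toxicity in this test:
Compound 1 `c1ccc(CNc2nc(Nc3ccccc3)nc3ccccc23)cc1`: > 10000 nM (a limit)
Compound 2 `OCCCNc1nc(NCc2ccccc2)c2ccccc2n1`: > 10000 nM (a limit)
Compound 3 `Oc1cccc(Nc2nc(NCc3ccccc3)c3ccccc3n2)c1`: 10000 nM

Within the data shown here, compound 2 has only a limit in this assay, not a number, and compound 1 is the one other compound with a limit. The evidence on this is the limit of > 10000 nM in this assay, at which 2 of the 3 values shown sit. The step now followed leads to compound 4 `OCCCNc1nc(Nc2cccc(F)c2)c2ccccc2n1`, with 3-fluorophenyl in place of benzyl on a nitrogen on an aromatic ring. Among the measured compounds shown here, no measured step makes this change. The three that exist give no size: a step that the two limits leave unreadable from compound 1 to compound 2, a number no higher from compound 1 to compound 3 (the limit leaves the size open) and a number no higher from compound 2 to compound 3 (the limit leaves the size open). For the measured compounds named here, the only true number belongs to compound 3, at 10000 nM. No step beyond the scatter is therefore expected in this assay, and no direction can be given. The expected step is a number no higher from compound 2 to compound 4 (the limit leaves the size open). For compound 4 the estimated value is 10000 nM. The expected range for compound 4 runs from 4000 nM to 25000 nM, and a report as a limit would be no surprise.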

Compound 4, half-maximal cytotoxic concentration: > 10000 nM
Compound 4 gave a limit, no number; the forecaster's own chance of this, stated with the estimate: 70%; the middle value sits exactly at the limit.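

In this assay, compound 2 and compound 4 are both reported as limits, and no step can be read between them. The compounds shown leave open what true values compound 1, compound 2 and compound 4 have, as all three rest on the same limit: the limit of > 10000 nM in this assay, at which 3 of the 4 values shown sit.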